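A few compounds are considered here, and "the series" means these few. Any claim that something is new, unique, unknown or untested is made for them only; others in the source may bear on it.

Measured so far in a physicochemical assay for solubility, using the shake flask method, in simulated intestinal fluid, measured as kinetic solubility, with a stated time of 2 h, at 25 degrees C, at pH 6.5; a higher number here means a more soluble compound, a lower number a less soluble compound:
Compound 1 `Cc1nc(C#N)c(N)c2c1C(=O)N(Cc1ccccc1)C2=O`: < 5000 nM (a limit of the assay, not a number)
Compound 2 `Cc1nc(C(=O)O)c(N)c2c1C(=O)N(Cc1ccccc1)C2=O`: 177000 nM
Compound 3 `CNC(=O)c1nc(C)c2c(c1N)C(=O)N(Cc1ccccc1)C2=O`: 41000 nM

Of the two values that are true numbers, the higher belongs to compound 2, at 177000 nM. The nearest is that of compound 3, at 41000 nM. The remaining value, that of compound 1, is the limit.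

The step followed here leads to compound 4 `Cc1nc(C(=O)N(C)C)c(N)c2c1C(=O)N(Cc1ccccc1)C2=O`. The change is dimethylamino in place of hydroxy on a carbonyl carbon, which also reads as carboxy to dimethylcarbamoyl.

Within the data shown here, the closest precedent is the replacement of hydroxy by methylamino on that same carbonyl carbon, which gave a 4.3-fold lower number from compound 2 to compound 3 (0.64 log units; beyond the scatter). The two steps that start from the limit, an at least 35-fold higher number from compound 1 to compound 2 (1.54 log units; beyond the scatter) and an at least 8.2-fold higher number from compound 1 to compound 3 (0.91 log units; beyond the scatter), place the carboxy and methylcarbamoyl compounds in the same order. Among the measured compounds shown here, no measured compound carries dimethylcarbamoyl, so the expectation rests on this single precedent. A modest drop in this assay, beyond the scatter and similar in size to the methylamino step, is therefore expected. The estimated step is a 5.1-fold lower number from compound 2 to compound 4 (0.70 log units; beyond the scatter). For compound 4 the estimated value is 35000 nM, with an expected range of 11000 nM to 110000 nM.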

Compound 4, solubility: 172000 nM
Compound 4: middle estimate off by 4.9-fold (0.69 log units), on the low side; the measured number lies above the stated range.
By their numbers in this assay, from the lowest: compound 3; then compounds 4 and 2 (each within the scatter of the next). At a limit, below all of these: compound 1.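

In this assay, dimethylamino in place of hydroxy on the carbonyl carbon gives a 1.0-fold lower number from compound 2 to compound 4 (0.01 log units; within the scatter), so at this position a number at the level of compound 2 does not depend on keeping the carboxy group. The two amides do not behave alike, and the methylamino step therefore did not carry over to the dimethylcarbamoyl group: methyl in place of hydrogen on the amide-type nitrogen gives a 4.2-fold higher number from compound 3 to compound 4 (0.62 log units; beyond the scatter), a gap that one methyl accounts for in this pair alone. Compound 1 stands at a limit, not a number, so the step that replaces its cyano group, an at least 34-fold higher number from compound 1 to compound 4 (1.53 log units; beyond the scatter), can be read only as a bound: the limit of < 5000 nM in this assay, at which 1 of the 4 values shown sits.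

The compounds shown leave open whether the higher number follows from having two alkyl groups on that nitrogen, as a diethylamino group or a longer chain would test, and where a plain amino group in place of hydroxy would fall. They also give no reason for the gap between compound 3 and compound 4, which rests on this one pair.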